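Cytotoxicity notes: compound 3 to compound 4

The source may report more compounds than this note shows. Statements on the series, on what has been measured and on what is new or still open speak of the compounds shown alone.

Compound 1 `Cc1cc(NC(=O)Nc2ccc(C)c(Cl)c2)c2ccccc2n1` gives > 25000 nM (a limit)
Compound 2 `CC(=O)c1ccc(NC(=O)Nc2cc(C)nc3ccccc23)cc1` gives 22000 nM (a number)
Compound 3 `Cc1cc(NC(=O)Nc2ccc(N(C)C)cc2)c2ccccc2n1` gives > 25000 nM (a limit)
Compound 4 `Cc1cc(NC(=O)Nc2ccc(OC(F)(F)F)cc2)c2ccccc2n1` has not been measured yet

Compound 3 gives > 25000 nM in an ADME assay on BJ cells (Homo sapiens) for cytotoxicity, with a stated time of 72 h (on this read-out higher numbers stand for an effect only at larger amounts of compound and lower numbers for an effect already at smaller amounts), and this is a limit, not a number. Its place is the limit of > 25000 nM in this assay, at which 2 of the 3 values shown sit, and it has no exact position there.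

Compound 4 has trifluoromethoxy in place of dimethylamino on an aromatic carbon and the rest of the structure is unchanged. Among the measured compounds shown here, one measured step bears on this, an exchange on the same aromatic carbon. It is an at least 1.1-fold higher number from compound 2 to compound 3 (0.05 log units; that floor lies within the scatter) and it gives only a floor for its size. For the measured compounds named here, compound 2 gives 22000 nM as the sole exact number.

No step beyond the scatter is therefore expected in this assay and no direction is favoured. The estimated change is an at least 1.1-fold lower number from compound 3 to compound 4 (0.05 log units; that floor lies within the scatter) and it is expected to stay small. The estimate for compound 4 is 22000 nM with an expected range from 9000 nM to 50000 nM and a report as a limit is also likely.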

Compound 4, half-maximal effective concentration: 25000 nM
The estimate for compound 4 lay 1.1-fold (0.06 log units) below the measured number; measured number inside the range.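

In this assay, trifluoromethoxy in place of acetyl on this aromatic carbon can now be read between two exact numbers, and it is a 1.1-fold higher number from compound 2 to compound 4 (0.06 log units; within the scatter). Acetyl and trifluoromethoxy therefore cannot be told apart in this read-out, which the earlier compounds could not show, as compound 2 alone had an exact number among the compounds differing only at this carbon. The other new step cannot be read in its size, as it is a number no higher from compound 3 to compound 4 (the limit leaves the size open), so dimethylamino cannot be placed against trifluoromethoxy, and the result remains bounded by a limit: the limit of > 25000 nM in this assay, at which 2 of the 4 values shown sit.

Open, as far as these compounds go, is whether a carboxylic acid or a longer alkyl chain on this aromatic carbon would move the number beyond the scatter in this assay. Also open, from the compounds shown here alone, is whether an amine placed on the shared core would do so.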